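Dropping a Chloro Substituent: Expected Cytotoxicity of Compound 4

The compounds below may be only part of what the source reports. "The series", "measured", "known", "first", "only" and "open" are said of these compounds alone.

Compound 1: `CCOC(=O)c1c(-c2c(Cl)c3ccccc3oc2=O)nn(-c2cccc(Cl)c2)c1C(=O)OCC` gives 24000 nM in a functional assay on DU-145 cells (Homo sapiens) for cytotoxicity, read by MTT assay, with a stated time of 48 h; a lower number here means a stronger inhibitor, a higher number a weaker inhibitor.
Compound 2: `CCOC(=O)c1c(-c2c(Cl)c3ccccc3oc2=O)nn(-c2ccc(Br)cc2)c1C(=O)OCC` gives 32000 nM in this assay.
Compound 3: `COC(=O)c1c(-c2cc3ccccc3oc2=O)nn(-c2ccccc2)c1C(=O)OC` gives 30000 nM in this assay.

Compound 2 has the highest of the three numbers, yet its gaps to compound 3 and to compound 1 both lie within the scatter, so no ordering can be read from them. Compound 4 `CCOC(=O)c1c(-c2cc3ccccc3oc2=O)nn(-c2ccc(Br)cc2)c1C(=O)OCC` differs from compound 2 by hydrogen in place of chloro on an aromatic carbon. Among the measured compounds shown here, the only single-point step available, a 1.3-fold higher number from compound 1 to compound 2 (0.12 log units; within the scatter), concerns the aryl group on the nitrogen and not this site. Compound 3 also lacks the chloro but differs from compound 2 in two further places, so its value shows only a number close to that of compound 2. For the measured compounds named here, no measured step thus bears on this change, and the step of no change at the digits printed from compound 2 to compound 4 (within the scatter) is expected to stay within the scatter. Compound 4 is estimated at 32000 nM, between 15000 nM and 68000 nM.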

Compound 4, half-maximal inhibitory concentration: 61000 nM
Estimate against measurement, compound 4: 1.9-fold (0.28 log units) below, within the range that was stated.
By their numbers in this assay, from the lowest: compounds 1, 3, 2 and 4 (each within the scatter of the next, the first and the last beyond it).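

The step of a 1.9-fold higher number from compound 2 to compound 4 (0.28 log units; within the scatter) is the only one among the compounds shown that reads this site directly, in this assay. Hydrogen in place of chloro on this aromatic carbon, opposite the ring oxygen, therefore gives no change that can be told from the scatter, with the 4-bromophenyl group held fixed. No measurement at hand offers a reason for this result. From the compounds shown here alone, whether a methyl group, a methoxy group or an amine at this carbon would give a different number remains open. So does whether the same exchange reads alike with the 3-chlorophenyl group of compound 1 on the nitrogen.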